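A few compounds are considered here, and "the series" means these few. Any claim that something is new, unique, unknown or untested is made for them only; others in the source may bear on it.

Series in a functional assay on MGC-803 cells (Homo sapiens) for antiproliferative activity, read by CellTiter-Glo, with a stated time of 72 h; a higher number here means a weaker inhibitor, a lower number a stronger inhibitor:
- compound 1 `O=C(NO)c1ccc(/C=C/c2ccnc(-c3cccc(O)c3)c2)cc1` gives 2100 nM
- compound 2 `O=C(NO)c1ccc(/C=C/c2ccnc(-c3ccc(F)cc3)c2)cc1` gives > 10000 nM, which is a limit of the assay and not a number
- compound 3 `Cc1ccc(-c2cc(/C=C/c3ccc(C(=O)NO)cc3)ccn2)cc1` gives 1910 nM

Compound 3 cannot be separated from compound 1, with a 1.1-fold lower number from compound 1 to compound 3 (0.04 log units; within the scatter). Among the measured compounds shown here, these are the only two numeric values.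

Compound 4 `O=C(NO)c1ccc(/C=C/c2ccnc(-c3ccc(C(F)(F)F)cc3)c2)cc1` carries trifluoromethyl in place of methyl on an aromatic carbon, para to a large group (trifluoromethyl in place of methyl on an aromatic carbon).

The closest measured change at this place is an at least 5.2-fold lower number from compound 2 to compound 3 (0.71 log units; beyond the scatter), where methyl replaces fluoro. A second step, an at least 4.7-fold higher number from compound 1 to compound 2 (0.67 log units; beyond the scatter), also ends at the fluoro compound. Neither step involves trifluoromethyl, so both offer only indirect guidance. Compound 3 is the methyl member, and leaving methyl for a fluorine-bearing group is tentatively expected to raise the number modestly in this assay. Compound 4 may also read out only at the limit of > 10000 nM in this assay, at which 1 of the 3 values shown sits.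

The expected change is a 1.8-fold higher number from compound 3 to compound 4 (0.26 log units; within the scatter). For compound 4 the estimated value is 3500 nM, with an expected range of 1200 nM to 10000 nM.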

Compound 4, half-maximal inhibitory concentration: > 10000 nM
Compound 4 gave a limit, no number; the forecaster's own chance of this, stated with the estimate: 25%; at least 2.8-fold (0.45 log units) between middle value and limit.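

In this assay, among the compounds shown here, the trifluoromethyl result shows that this place, on an aromatic carbon para to a large group, does not accept every replacement of methyl: there is an at least 5.2-fold higher number from compound 3 to compound 4 (0.71 log units; beyond the scatter), so the fluoro compound is no longer the only member with this outcome. Compound 4 gives > 10000 nM, which is a limit of the assay and not a number. For the compounds shown here, the step from compound 2 to compound 4 cannot be read, and at this place only the methyl member has a numeric value so far: the limit of > 10000 nM in this assay, at which 2 of the 4 values shown sit.

On these data alone, whether fluoro and trifluoromethyl differ at all stays open, since both sit at the limit. Also open, as far as these compounds go, is whether an ethyl group, a methoxy group, an amine or a carboxylic acid at this place would give a numeric value.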